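The source may report more compounds than this note shows. Statements on the series, on what has been measured and on what is new or still open speak of the compounds shown alone.

Working notes on the series. Compound 1 `Cc1cccc(-c2noc(C3CC(=O)N(c4ccc(F)cc4)C3)n2)n1` is one of two measured compounds in a physicochemical assay for solubility, read by HPLC; on this read-out lower numbers stand for lower solubility and higher numbers for higher solubility; compound 1 gives 26000 nM. Its nearest neighbour is compound 2 `O=C1CC(c2nc(-c3ccccn3)no2)CN1c1ccc(F)cc1`, and in this assay compound 2 gives 26000 nM. The single measured step, hydrogen in place of methyl on an aromatic carbon, gives no change at the digits printed from compound 1 to compound 2 (within the scatter), so compound 1 stands level with compound 2 on the numbers shown.

Compound 3 `Cc1cccc(-c2noc(C3CC(=O)N(c4ccc(Cl)cc4)C3)n2)n1` has not yet been measured in this assay. It differs from compound 1 by chloro in place of fluoro on an aromatic carbon of a six-membered aromatic ring of carbon only, para to a large group; one bond further out this reads 4-fluorophenyl to 4-chlorophenyl.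

For the measured compounds named here, no measured step touches this ring, and the one step on record, no change at the digits printed from compound 1 to compound 2 (within the scatter), concerns a different position and does not bear on the halogen exchange. The expectation for compound 3 therefore rests on compound 1 alone, with a modest downward step estimated as a 1.7-fold lower number from compound 1 to compound 3 (0.24 log units; within the scatter). Compound 3 is expected to give about 15000 nM in this assay, within a range of 6000 nM to 35000 nM.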

Compound 3, solubility: 26000 nM
The estimate for compound 3 lay 1.7-fold (0.24 log units) below the measured number, and the stated range covers the measured number.
By their numbers in this assay, from the lowest: compounds 1, 2 and 3 (each within the scatter of the next).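

The halogen position now has a measured step of its own: in this assay, 4-fluorophenyl to 4-chlorophenyl gives no change at the digits printed from compound 1 to compound 3 (within the scatter) on the shared core. For the compounds shown here, the only earlier step concerned hydrogen in place of methyl, so it gave no reading for this place on the six-membered aromatic ring of carbon only, para to a large group. For this single pair, the exchange of fluoro for chloro cannot be told apart on this read-out, and nothing on hand accounts for that reading.

The compounds shown leave open whether a group other than a halogen at this place, such as an amine, a carboxylic acid or a methoxy group, would give a step beyond the scatter. They also leave open whether the same exchange reads alike on compound 2, where hydrogen stands in place of the methyl of compound 1.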